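A few compounds are considered here, and "the series" means these few. Any claim that something is new, unique, unknown or untested is made for them only; others in the source may bear on it.

Compound 1 `CC(C(=O)NCc1ccc(C(F)(F)F)cc1)c1ccc(NS(C)(=O)=O)c(F)c1` gives 660 nM in an assay on CHO cells for displacement of a labelled ligand from transient receptor potential cation channel subfamily V member 1 (Rattus norvegicus); a lower number here means a stronger inhibitor, a higher number a weaker inhibitor; compound 2 `Cc1ccc(CNC(=O)C(C)c2ccc(NS(C)(=O)=O)c(F)c2)cc1` gives 3100 nM in this assay.

Among these two numbers, compound 2 is the higher, the weaker inhibitor. Compound 3 `CC(C)c1ccc(CNC(=O)C(C)c2ccc(NS(C)(=O)=O)c(F)c2)cc1` differs from compound 2 by isopropyl in place of methyl on an aromatic carbon. For the measured compounds named here, the one measured step that touches this place, a 4.7-fold higher number from compound 1 to compound 2 (0.67 log units; beyond the scatter), shows that the group at this place matters within the shared core, but it swaps a different pair of groups, so it only hints at direction. A modest lowering is therefore expected, a 2.1-fold lower number from compound 2 to compound 3 (0.32 log units; beyond the scatter). Compound 3 is estimated at 1500 nM, between 500 nM and 4500 nM.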

Compound 3, inhibition constant: 127 nM
Compound 3: the middle estimate sits 12-fold (1.07 log units) above what was measured; measured number outside the range, below it.
By their numbers in this assay, from the lowest: compound 3; then compound 1; then compound 2.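

Putting isopropyl in place of methyl on this aromatic carbon brings a 24-fold lower number from compound 2 to compound 3 (1.39 log units; beyond the scatter) in this assay, and putting it in place of trifluoromethyl brings a 5.2-fold lower number from compound 1 to compound 3 (0.72 log units; beyond the scatter). This place therefore responds far more strongly than the earlier step suggested, and isopropyl gives the lowest number of the three groups, with both of its steps beyond the scatter. Nothing available explains this gain.

As far as these compounds go, whether a tert-butyl group, a longer chain or a methoxy group here would lower the number further remains open. So does whether the gain from isopropyl would carry over to a different core.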